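Bromo to Chloro on the Haloacetamide Arm

The source may hold more compounds than are shown below. What is called first, only, known or untested is meant among the compounds shown, and "the series" means these compounds.

compound 1 `COc1ccc(C(=O)NC(N)=O)cc1NC(=O)C(C)Br`: > 20000 nM
compound 2 `NC(=O)NC(=O)c1cc(NC(=O)CBr)ccc1F`: < 10 nM
compound 3 `COc1ccc(C(=O)NC(N)=O)cc1NC(=O)C(C)Cl`: > 20000 nM

Of the compounds shown here, three have been measured in a functional assay on CCRF-CEM cells (Homo sapiens) for antiproliferative activity, read by trypan blue exclusion, with a stated time of 72 h; on this read-out lower numbers stand for stronger inhibition and higher numbers for weaker inhibition. For compound 1 the value > 20000 nM is a limit of the assay. For compound 3 the value > 20000 nM is likewise a limit. For compound 2 the value < 10 nM is a limit as well. Two values sit at the limit of > 20000 nM in this assay, at which 2 of the 3 values shown sit, and one at the limit of < 10 nM in this assay, at which 1 of the 3 values shown sits. How the core of compound 2 differs from the core of compound 1 is not broken down here. From compound 1 to compound 3 the change is chloro in place of bromo on a saturated chain carbon bound to a carbonyl carbon and a saturated chain carbon and the step is a step that the two limits leave unreadable from compound 1 to compound 3. Compound 4 `NC(=O)NC(=O)c1cc(NC(=O)CCl)ccc1F`, not yet measured, differs from compound 2 by chloro in place of bromo on a saturated chain carbon bound to a carbonyl carbon, the same kind of change, though here the place is a saturated chain carbon bound to a carbonyl carbon, whereas in compound 1 and compound 3 it is bound to a carbonyl carbon and a saturated chain carbon. The earlier step has no readable size, so the expectation rests on compound 2 alone. Compound 2 reached the limit < 10 nM. The step is expected to be a loss of an at least 10-fold higher number from compound 2 to compound 4 (1.00 log units; beyond the scatter). Compound 4 is estimated at 100 nM, between 10 nM and 2000 nM.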

Compound 4, half-maximal inhibitory concentration: 7680 nM
Compound 4: middle estimate off by 77-fold (1.89 log units), on the low side, and the stated range ends below it.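

In this assay, chloro in place of bromo on a saturated chain carbon bound to a carbonyl carbon gives an at least 760-fold higher number from compound 2 to compound 4 (2.88 log units; beyond the scatter), a large loss whose size is only a lower bound, as the value of compound 2 is a limit: the limit of < 10 nM in this assay, at which 1 of the 4 values shown sits.

The same change on the core of compound 1 cannot be read, because compound 1 and compound 3 both sit at a limit: the limit of > 20000 nM in this assay, at which 2 of the 4 values shown sit.

So the series shows this loss on one core only and does not show that it carries over to another.

On these data alone, it remains open whether iodo or an amine in place of bromo on that carbon would hold the activity of compound 2. Also open, as far as these compounds go, is which of the differences between the core of compound 1 and the core of compound 2 separates their values.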